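Methyl on the aryl piperazine of the oxazole series

A few compounds are considered here, and "the series" means these few. Any claim that something is new, unique, unknown or untested is made for them only; others in the source may bear on it.

Compound 1, `CCCc1nc(-c2ccccc2)c(CNCCCN2CCN(c3ccccc3)CC2)o1`, stands lowest of the three numbers in an assay on HEK293 cells for inhibition of Voltage-dependent T-type calcium channel subunit alpha-1G (Homo sapiens), read by fluorescence, tested at 10 uM (a higher number here means more inhibition at the concentration tested (going by the name of the read-out), a lower number less inhibition), where compound 1 gives 43.7%. Compound 2, `CCCc1nc(-c2ccccc2)c(CNCCN2CCN(c3ccccc3F)CC2)o1`, gives 46.5% in this assay, within the scatter of compound 1; compound 3, `CCCc1nc(-c2ccccc2)c(CNCCN2CCN(c3cccc(C(F)(F)F)c3)CC2)o1`, gives 56.3%, beyond the scatter of compound 1. For the measured compounds named here, the only measured step on the aryl piperazine, a number 9.8 percentage points higher from compound 2 to compound 3 (within the scatter), concerns a different group at a different place on the ring. Compound 4, `CCCc1nc(-c2ccccc2)c(CNCCCN2CCN(c3ccc(C)cc3)CC2)o1`, differs from compound 1 by methyl in place of hydrogen on an aromatic carbon. Going by the values given here, no measured step bears directly on this change; the one ring step stayed within the scatter, so a step of similar size is expected, a number 4.3 percentage points higher from compound 1 to compound 4 (within the scatter). Compound 4 is estimated at 48%, range 35% to 62%.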

Compound 4, a percentage reported as inhibition, at one concentration (the size of the read-out at that concentration, not a potency): 53.9%
Compound 4: middle estimate off by 5.9 percentage points, on the low side, within the range that was stated.
By their numbers in this assay, from the lowest: compounds 1, 2, 4 and 3 (each within the scatter of the next, the first and the last beyond it).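

In this assay, methyl in place of hydrogen on an aromatic carbon, para to a large group, gives a number 10.2 percentage points higher from compound 1 to compound 4 (beyond the scatter), a modest change from phenyl to 4-methylphenyl. For the compounds shown here, this is the first single-place step on this ring printed as beyond the scatter, so one added carbon at this place is enough to register. No measurement at hand accounts for the step.

Open, as far as these compounds go, is whether a longer chain such as ethyl, or an amine, at this place moves the number in the same direction. Also open, from the compounds shown here alone, is whether methyl at another place on the ring does so.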